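A Second Methyl Ether on the Shared Core

The compounds below may be only part of what the source reports. "The series", "measured", "known", "first", "only" and "open" are said of these compounds alone.

Compound 1 `O=C1C[C@H]2O[C@H]([C@H](O)c3ccccc3)[C@H](O)[C@H]2O1` carries two free hydroxy groups on its core. In a functional assay on HL-60 cells (Homo sapiens) for inhibition, read by MTT assay, with a stated time of 72 h (a higher number here means a weaker inhibitor, a lower number a stronger inhibitor), compound 1 gives only a limit, > 100000 nM. Compound 2 `CO[C@H](c1ccccc1)[C@H]1O[C@@H]2CC(=O)O[C@@H]2[C@H]1O` has one of these hydroxy groups converted to a methoxy group. In this assay compound 2 gives 2960 nM. The step of an at least 33-fold lower number from compound 1 to compound 2 (1.52 log units; beyond the scatter) is read against (the limit of > 100000 nM in this assay, at which 1 of the 2 values shown sits), so its full size is not known; only its smallest possible size is. Among the numbers shown, compound 2 holds the only measured value; the other entry is a limit.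

Compound 3 `CO[C@@H]1[C@H]2OC(=O)C[C@H]2O[C@@H]1[C@H](OC)c1ccccc1` is not yet measured. It differs from compound 2 by methyl in place of hydrogen on an oxygen on a saturated carbon. Among the measured compounds shown here, the only step that bears on it is the one from compound 1 to compound 2, which was large and pointed toward a lower number, although it concerned the other hydroxy group. A further change in the same direction, smaller than the first, seems the most reasonable reading, with wide uncertainty. Compound 3 is therefore expected to show the step of a 2.0-fold lower number from compound 2 to compound 3 (0.30 log units; within the scatter). For compound 3 the expected value in this assay is 1500 nM, most likely lying between 300 nM and 8000 nM.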

Compound 3, half-maximal inhibitory concentration: 2210 nM
The estimate for compound 3 lay 1.5-fold (0.17 log units) below the measured number, and the stated range covers the measured number.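

In this assay the exchange of hydroxy to methoxy now has a second reading, at the other hydroxy group of the shared core, and there it gives a 1.3-fold lower number from compound 2 to compound 3 (0.13 log units; within the scatter). At this oxygen on a saturated carbon, compound 2 and compound 3 therefore cannot be told apart, whereas the same exchange at the first oxygen gave an at least 33-fold lower number from compound 1 to compound 2 (1.52 log units; beyond the scatter). The same change thus does not read alike at the two oxygens of this core, although the first step can be bounded from one side only: the limit of > 100000 nM in this assay, at which 1 of the 3 values shown sits.

Going by these compounds, it remains open whether any group on this oxygen would leave the number within the scatter, or whether only methyl does so; an acetyl group, an ethyl group or a longer chain in its place would address that. On these data alone, it is also open how a methyl ether at this oxygen alone, with the other hydroxy group left free, would compare with compound 1, which would show whether this position has any bearing on the number when the first oxygen carries hydrogen.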